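A few compounds are considered here, and "the series" means these few. Any claim that something is new, unique, unknown or untested is made for them only; others in the source may bear on it.

Compound 1 `CS(=O)(=O)NNc1nonc1/C(=N/O)Nc1ccc(F)c(Br)c1` gives in an assay on HeLa cells for inhibition of Indoleamine 2,3-dioxygenase 1 (Homo sapiens), read by spectrophotometry, with a stated time of 24 h (on this read-out lower numbers stand for an effect already at smaller amounts and higher numbers for an effect only at larger amounts of compound), a value that is a limit of the assay, > 800 nM.
Compound 2 `NS(=O)(=O)NNc1nonc1/C(=N/O)Nc1ccc(F)c(Br)c1` gives 101 nM.
Compound 3 `CCNS(=O)(=O)CCNc1nonc1/C(=N/O)Nc1ccc(F)c(Br)c1` gives 41 nM.

Compound 3 stands lowest of the two numbers in this assay; its nearest neighbour is compound 2, and the step is a 2.5-fold lower number from compound 2 to compound 3 (0.39 log units; beyond the scatter). The other steps, an at least 7.9-fold lower number from compound 1 to compound 2 (0.89 log units; beyond the scatter) and an at least 19-fold lower number from compound 1 to compound 3 (1.29 log units; beyond the scatter), are read against the limit (the limit of > 800 nM in this assay, at which 1 of the 3 values shown sits).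

Compound 4 `C#CCNS(=O)(=O)CCNc1nonc1/C(=N/O)Nc1ccc(F)c(Br)c1` differs from compound 3 by ethynyl in place of methyl on a saturated chain carbon bound to a sulfonamide nitrogen. All measured steps concern the group on the ring nitrogen; none touches the alkyl on the sulfonamide nitrogen, so they bear only indirectly here. The step is therefore expected to stay within the scatter, a 1.0-fold lower number from compound 3 to compound 4 (0.01 log units; within the scatter). Compound 4 is estimated at 40 nM in this assay, with a range from 15 nM to 110 nM.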

Compound 4, half-maximal effective concentration: 33 nM
Beside the measured number, compound 4's estimate is 1.2-fold (0.08 log units) above it; measured number inside the range.
By their numbers in this assay, from the lowest: compounds 4 and 3 (each within the scatter of the next); then compound 2. At a limit, above all of these: compound 1.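

In this assay, the alkyl on the sulfonamide nitrogen now proves open to change, since ethyl to propargyl stays within the scatter (a 1.2-fold lower number from compound 3 to compound 4 (0.09 log units; within the scatter)). With propargyl in that place, the 2-(propargylsulfamoyl)ethyl group still separates from the earlier groups on the ring nitrogen (a 3.1-fold lower number from compound 2 to compound 4 (0.49 log units; beyond the scatter); an at least 24-fold lower number from compound 1 to compound 4 (1.38 log units; beyond the scatter)). Compound 1 stands at a limit, so the last step is only a bound: the limit of > 800 nM in this assay, at which 1 of the 4 values shown sits.

Going by these compounds, what an amine or a carboxylic acid would do on a saturated chain carbon bound to a sulfonamide nitrogen remains open, as does a longer chain in that place.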